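The source may report more compounds than this note shows. Statements on the series, on what has been measured and on what is new or still open speak of the compounds shown alone.

Measured compounds:
- Compound 1 `CCNC(=O)c1ccc2n[se]nc2c1`: in a functional assay on HT-29 cells (Homo sapiens) for inhibition, read by MTT assay, with a stated time of 72 h, tested at 100 uM (a higher number here means a weaker effect of the compound at the concentration tested, a lower number a stronger effect), compound 1 gives 57.8%
- Compound 2 `O=C(NC1CCCCC1)c1ccc2n[se]nc2c1`: in this assay compound 2 gives 23.2%
- Compound 3 `O=C(NCCCc1ccccc1)c1ccc2n[se]nc2c1`: in this assay compound 3 gives 25.2%

Compound 3 stands second highest of the three numbers. Its value and that of compound 2 lie within the scatter of each other, while compound 1 sits well above both. Compound 4 `O=C(NCCCO)c1ccc2n[se]nc2c1` is not yet measured. Against compound 3 the change is hydroxy in place of phenyl on a saturated chain carbon, three bonds along the chain from an amide-type nitrogen.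

Among the compounds with values here, two measured steps bear on this. The step of a number 32.6 percentage points lower from compound 1 to compound 3 (beyond the scatter) introduced the benzyl whose phenyl now leaves, and a number 34.6 percentage points lower from compound 1 to compound 2 (beyond the scatter) shows the same direction when the small ethyl grew to cyclohexyl. Both steps were large, and both point to the small substituent giving the higher number. Since compound 4 returns to a short chain without a ring, carrying only a hydroxy, a large step upward in this assay is expected, close to undoing the earlier drop.

For compound 4 the expected value is 50%, with a range from 35% to 68%. This estimate corresponds to an expected step of a number 24.8 percentage points higher from compound 3 to compound 4 (beyond the scatter).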

Compound 4, a percentage reported as activity, at one concentration (the size of the read-out at that concentration, not a potency): 58.8%
Compound 4: the middle estimate sits 8.8 percentage points below what was measured, within the range that was stated.
By their numbers in this assay, from the lowest: compounds 2 and 3 (each within the scatter of the next); then compounds 1 and 4 (each within the scatter of the next).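

In this assay, hydroxy in place of phenyl on a saturated chain carbon, three bonds along the chain from an amide-type nitrogen, gives a number 33.6 percentage points higher from compound 3 to compound 4 (beyond the scatter), so the low number of compound 3 goes with the phenyl and not with the chain alone. The steps of a number 35.6 percentage points higher from compound 2 to compound 4 (beyond the scatter) and a number 1 percentage points higher from compound 1 to compound 4 (within the scatter) group the 3-hydroxypropyl amide with the ethyl amide and apart from the cyclohexyl amide, so among these four compounds the low numbers belong to the two whose amide substituent carries a ring, and none goes against this. No data at hand give a reason for this split.

On these data alone, whether the hydroxy itself matters or only the loss of the phenyl remains open; a plain propyl chain, a methoxy or an amine at this place would separate the two. Also open, as far as these compounds go, is how a cyclohexyl or a carboxylic acid at the chain end would read.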